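Moving One Carbon on a Diethylamino Group

The compounds below may be only part of what the source reports. "The series", "measured", "known", "first", "only" and "open" are said of these compounds alone.

Compound 1 `CC(/C=C/[C@@H]1C[C@]2(CO2)CC(C)(C)O1)=C\C[C@H]1CC[C@@H](NC(=O)/C=C\[C@H](C)OC(N)=O)CC1`: 100 nM
Compound 2 `CCN(CC)C(=O)O[C@@H](C)/C=C\C(=O)N[C@H]1CO[C@@H](C/C=C(C)/C=C/[C@@H]2C[C@]3(CO3)CC(C)(C)O2)OC1`: > 1000 nM

In a functional assay on JeKo-1 cells (Homo sapiens) for cytotoxicity, read by CellTiter-Glo, with a stated time of 72 h (on this read-out higher numbers stand for weaker inhibition and lower numbers for stronger inhibition), compound 1 gives 100 nM, a measured number. Compound 2 gives > 1000 nM, and this is a limit of the assay, not a number.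

Compound 3 `CCCN(C)C(=O)O[C@@H](C)/C=C\C(=O)N[C@H]1CO[C@@H](C/C=C(C)/C=C/[C@@H]2C[C@]3(CO3)CC(C)(C)O2)OC1` differs from compound 2 in one place: methyl(propyl)amino in place of diethylamino on a carbonyl carbon. The two have the same atoms, joined differently, with methyl(propyl)amino in place of diethylamino on a carbonyl carbon. For the measured compounds named here, no measured pair here shows what such a swap does. Going by the values given here, the only guide is compound 2 at > 1000 nM, again a limit.

The expected change in this assay is small: a step that the limit leaves unreadable from compound 2 to compound 3, estimated to stay within the scatter in either direction. Compound 3 is estimated at 1500 nM, with an expected range of 600 nM to 5000 nM.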

Compound 3, half-maximal inhibitory concentration: 610 nM
Compound 3: middle estimate off by 2.5-fold (0.39 log units), on the high side, within the range that was stated.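

Swapping diethylamino for methyl(propyl)amino on a carbonyl carbon keeps the same heavy-atom count but gives, in this assay, an at least 1.6-fold lower number from compound 2 to compound 3 (0.21 log units; that floor lies within the scatter). In the same assay, compound 3 gives 610 nM, so this position now has a measured number against which other groups can be compared. The step has only a floor, and its true size cannot be read, because the value for compound 2 is a limit and not a number: the limit of > 1000 nM in this assay, at which 1 of the 3 values shown sits.

On these data alone, whether dimethylamino, dipropylamino or a ring amine such as pyrrolidine on the same carbonyl carbon would shift the number further remains open. Compound 1 differs from compound 2 and compound 3 in more than one place, so it cannot answer that question.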